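The source may hold more compounds than are shown below. What is called first, only, known or untested is meant among the compounds shown, and "the series" means these compounds.

Measured compounds in a functional assay on PC-3 cells (Homo sapiens) for cytotoxicity, read by sulforhodamine B assay, with a stated time of 72 h; on this read-out lower numbers stand for stronger inhibition of growth and higher numbers for weaker inhibition of growth:

compound 1 `CC(=O)N1c2ccccc2CCC1C(=O)Nc1ccccc1O` — 70700 nM
compound 2 `CCCC(=O)N1c2ccccc2CCC1C(=O)Nc1cc(C(F)(F)F)cc(C(F)(F)F)c1` — 18600 nM
compound 3 `CCC(=O)N1c2ccccc2CCC1C(=O)Nc1ccccc1C(F)(F)F` — in this assay compound 3 gives only a limit, > 80000 nM

Compound 1 and compound 2 share the core of compound 1 and differ both in the acyl group on the ring nitrogen and in the aryl amide. In this assay compound 2 gives the lowest of the two numbers, with compound 1 standing a good way higher, beyond the scatter. For compound 3 only a limit is reported in this assay, (the limit of > 80000 nM in this assay, at which 1 of the 3 values shown sits), so it adds no number to the comparison.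

The unmeasured compound 4 `O=C(Nc1cc(C(F)(F)F)cc(C(F)(F)F)c1)C1CCc2ccccc2N1C(=O)c1cccc(Cl)c1` keeps the bis(trifluoromethyl)phenyl amide of compound 2 and changes only the acyl group: 3-chlorophenyl in place of propyl on a carbonyl carbon. Among the compounds with values here, no measured pair in this set isolates such a change at the carbonyl on the ring nitrogen, so there is no step to lean on. The expectation for compound 4 is therefore kept close to compound 2: a step of a 1.6-fold lower number from compound 2 to compound 4 (0.19 log units; within the scatter) that is estimated to stay within or only slightly beyond the scatter, with direction uncertain. Compound 4 is expected to give about 12000 nM in this assay, estimated between 4000 nM and 40000 nM.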

Compound 4, concentration for 50% growth inhibition: 1050 nM
Estimate against measurement, compound 4: 11-fold (1.06 log units) above, and the stated range ends above it.
By their numbers in this assay, from the lowest: compound 4; then compound 2; then compound 1. At a limit, above all of these: compound 3.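

Within the data shown here, with the bis(trifluoromethyl)phenyl amide held fixed, 3-chlorophenyl in place of propyl on a carbonyl carbon gives an 18-fold lower number from compound 2 to compound 4 (1.25 log units; beyond the scatter) in this assay, the first step in this set that reads one place alone. The earlier compounds shown here differ in the acyl group and the aryl amide together, so they gave this position no reading of its own; it now shows that the group on this carbonyl can by itself shift growth inhibition well beyond the scatter, and that an aromatic ring is accepted there in this assay. The change is a single swap of a whole group, so the share of the ring and the share of the chlorine cannot be told apart, and nothing measured here gives a reason for the step.

Open, from the compounds shown here alone, is whether a phenyl without chlorine, a 4-chlorophenyl, a benzyl or a longer chain on the same carbonyl would hold this gain. Also open, going by these compounds, is whether 3-chlorophenyl gives a step of similar size with the aryl amides of compound 1 and compound 3, or only with the bis(trifluoromethyl)phenyl amide.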